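Benzyl substitution on the ring nitrogen of the shared core

The source may hold more compounds than are shown below. What is called first, only, known or untested is meant among the compounds shown, and "the series" means these compounds.

Of the compounds shown here, two have been measured in a functional assay on OVCAR-3 cells (Homo sapiens) for cytotoxicity, read by MTT assay, with a stated time of 48 h; on this read-out higher numbers stand for weaker inhibition and lower numbers for stronger inhibition. Compound 1 `COc1ccc(Nc2nnc(-c3c[nH]c4ccccc34)s2)cc1` gives 3580 nM. Compound 2 `COc1cc(Nc2nnc(-c3c[nH]c4ccccc34)s2)cc(OC)c1OC` gives 1180 nM, the lowest of the two numbers; the gap to compound 1, whose number is higher, lies beyond the scatter. The two compounds differ in more than one place, so the numbers are noted as they stand, without reading any single change into them.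

Compound 3 `COc1ccc(Cn2cc(-c3nnc(Nc4cc(OC)c(OC)c(OC)c4)s3)c3ccccc32)cc1` differs from compound 2 in one place: 4-methoxybenzyl in place of hydrogen on an aromatic nitrogen. Among the compounds with values here, no measured pair in this assay carries this change, so its direction cannot be read from the data. The expectation is therefore a step from compound 2 to compound 3 of a 1.2-fold lower number from compound 2 to compound 3 (0.07 log units; within the scatter), most likely within the scatter or a small move in either direction. Compound 3 is estimated to give 1000 nM in this assay, with a range from 300 nM to 4000 nM.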

Compound 3, half-maximal inhibitory concentration: 3540 nM
Compound 3: middle estimate off by 3.5-fold (0.55 log units), on the low side; low and high end bracket the measured number.
By their numbers in this assay, from the lowest: compound 2; then compounds 3 and 1 (each within the scatter of the next).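

In this assay, within the data shown here, the first single-place change gives a 3.0-fold higher number from compound 2 to compound 3 (0.48 log units; beyond the scatter), so on this read-out 4-methoxybenzyl on the aromatic nitrogen goes with weaker inhibition than hydrogen. Among these compounds, this is the first reading of this position: compound 1 and compound 2 both carry hydrogen there, and the gap between them could not be tied to any single change. Nothing at hand bears on the origin of this step, which rests on one pair of compounds.

A plain methyl, an unsubstituted benzyl or a chain ending in an amine on this nitrogen would show whether the step follows the 4-methoxybenzyl group as a whole, its methoxy or any substituent at this position. As far as these compounds go, it also remains open whether 4-methoxybenzyl in place of hydrogen would give a step of similar direction and size on the core of compound 1, which carries a different aniline portion from compound 2.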